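The source may hold more compounds than are shown below. What is called first, only, known or untested is meant among the compounds shown, and "the series" means these compounds.

Values in a functional assay on the whole organism with Rattus norvegicus as the target; on this read-out higher numbers stand for an effect only at larger amounts of compound and lower numbers for an effect already at smaller amounts:
- Compound 1 `CCN(CCNC(=O)c1cc(Cl)c(N)cc1OC)Cc1ccccn1`: 30 mg/kg
- Compound 2 `CCNCCNC(=O)c1cc(Cl)c(N)cc1OC`: > 30 mg/kg, a limit
- Compound 3 `CCN(CCNC(=O)c1cc(Cl)c(N)cc1OC)Cc1cccc(OC)c1`: 1 mg/kg

Compound 3 has the lower of the two actual numbers, with the value of compound 2 being only a limit. Compound 4 `CCN(CCNC(=O)c1cc(Cl)c(N)cc1OC)Cc1cccc(Cl)c1` follows from compound 3 by chloro in place of methoxy on an aromatic carbon. For the measured compounds named here, no measured step makes this exchange. The nearest are a 30-fold lower number from compound 1 to compound 3 (1.48 log units; beyond the scatter) and an at least 30-fold lower number from compound 2 to compound 3 (1.47 log units; beyond the scatter), both large, and both change the whole group on the amine nitrogen. A much smaller step is therefore expected in this assay, with a slight rise at most and no firm direction. The expected step is a 1.5-fold higher number from compound 3 to compound 4 (0.18 log units; within the scatter). For compound 4 the estimated value is 1.5 mg/kg, with an expected range of 0.3 mg/kg to 8 mg/kg.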

Compound 4, dose for half-maximal effect: 0.58 mg/kg
Estimate against measurement, compound 4: 2.6-fold (0.41 log units) above; low and high end bracket the measured number.
By their numbers in this assay, from the lowest: compounds 4 and 3 (each within the scatter of the next); then compound 1.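

In this assay, chloro serves as well as methoxy at this place on the ring, since a 1.7-fold lower number from compound 3 to compound 4 (0.24 log units; within the scatter) is the whole effect of the exchange. The large distance from the pyridin-2-yl compound therefore survives without the methoxy oxygen, as a 52-fold lower number from compound 1 to compound 4 (1.71 log units; beyond the scatter) shows. The step of an at least 51-fold lower number from compound 2 to compound 4 (1.71 log units; beyond the scatter) starts from a limit of compound 2, not from a number: the limit of > 30 mg/kg in this assay, at which 1 of the 4 values shown sits.

Open, as far as these compounds go, is how a plain benzyl group on the amine nitrogen would compare with compounds 3 and 4. Also open, from the compounds shown here alone, is whether fluoro or trifluoromethyl at this place, or chloro on another ring carbon, reads the same.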